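The source may report more compounds than this note shows. Statements on the series, on what has been measured and on what is new or still open speak of the compounds shown alone.

In an assay on Jurkat cells for inhibition of integrin alpha-4/beta-1 (Homo sapiens) (on this read-out higher numbers stand for weaker inhibition and lower numbers for stronger inhibition), compound 1 `Cc1ccccc1NC(=O)N1CC=C(C(=O)NCc2ccc(NC(=O)CC(=O)O)cc2)[C@@H]1C(C)C` gives 110 nM. Compound 2 `Cc1ccccc1NC(=O)Nc1ccc(CNC(=O)C2=CCN(C(=O)CC(=O)O)[C@H]2C(C)C)cc1` reaches the limit of this assay, > 1000 nM, a boundary rather than a measured number. That boundary, (the limit of > 1000 nM in this assay, at which 1 of the 2 values shown sits), is where compound 2 sits. Compound 3 `Cc1ccccc1NC(=O)Nc1ccc(CNC(=O)C2=CCN(C(=O)CC(=O)O)[C@@H]2C(C)C)cc1` keeps every atom and bond of compound 2 (the two compounds have the same atoms and bonds and differ only in configuration as drawn: 1 of 1 stereo elements differ; a stereocentre at a saturated ring carbon is drawn S in compound 2 and R in compound 3). Within the data shown here, with no measured pair of this kind to lean on, the step from compound 2 to compound 3 is expected to be about an at least 2.5-fold lower number from compound 2 to compound 3 (0.39 log units; beyond the scatter), towards stronger inhibition, though a value at the limit again would not be surprising. Compound 3 is therefore estimated at 400 nM, between 60 nM and 3000 nM.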

Compound 3, half-maximal inhibitory concentration: 10 nM
Beside the measured number, compound 3's estimate is 40-fold (1.60 log units) above it; measured number outside the range, below it.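

In this assay the configuration drawn at this saturated ring carbon has a very large effect on its own, giving an at least 100-fold lower number from compound 2 to compound 3 (2.00 log units; beyond the scatter), towards stronger inhibition. Compound 2 carries a limit of the assay, > 1000 nM, not a measured number. The change can be put down to this stereocentre alone because nothing else separates the two structures: the fact that compounds 2 and 3 differ only in the configuration as drawn

The compounds shown leave open whether the R configuration would keep its advantage with a different group on this ring carbon, such as a phenyl group.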